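Replacing an ester with a 2-chlorobenzyl ether

A few compounds are considered here, and "the series" means these few. Any claim that something is new, unique, unknown or untested is made for them only; others in the source may bear on it.

The measured compounds, in a functional assay on U-251 cells (Homo sapiens) for antiproliferative activity, read by MTT assay, with a stated time of 24 h; on this read-out lower numbers stand for stronger inhibition and higher numbers for weaker inhibition:
- compound 1, `COc1cccc(C(=O)Oc2ccc3c(=O)c(-c4cc(OC)c(OC)cc4OC)coc3c2)c1`, gives only a limit, > 10000 nM.
- compound 2, `COc1cc(OC)c(-c2coc3cc(OCc4ccccc4F)ccc3c2=O)cc1OC`, gives 2890 nM.
- compound 3, `COc1cc(OC)c(-c2coc3cc(OCc4ccccc4C#N)ccc3c2=O)cc1OC`, gives 980 nM.

Compound 1 sits at the limit of > 10000 nM in this assay, at which 1 of the 3 values shown sits; for it only a limit and no number is known, so every step away from it can be read only as a lower bound. The unmeasured compound 4, `COc1cc(OC)c(-c2coc3cc(OCc4ccccc4Cl)ccc3c2=O)cc1OC`, differs from compound 1 in one place: 2-chlorobenzyl in place of (3-methoxyphenyl)carbonyl on an oxygen on an aromatic ring.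

Among the measured compounds shown here, two measured steps bear on this change, since both also exchange the (3-methoxyphenyl)carbonyl for a benzyl group carrying a single substituent. There is an at least 3.4-fold lower number from compound 1 to compound 2 (0.53 log units; beyond the scatter) and an at least 10-fold lower number from compound 1 to compound 3 (1.00 log units; beyond the scatter). Between those two benzyl ethers, a 2.9-fold lower number from compound 2 to compound 3 (0.47 log units; beyond the scatter) shows that the substituent itself matters, and within this small set the cyano version gives the lower number. A chloro substituent is neither of these, so compound 4 is expected to land between compound 2 and compound 3, giving an at least 5.5-fold lower number from compound 1 to compound 4 (0.74 log units; beyond the scatter). Compound 4 is therefore estimated at 1800 nM in this assay, with a likely range from 700 nM to 4500 nM.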

Compound 4, half-maximal inhibitory concentration: > 10000 nM
Compound 4 was reported as a limit; the forecaster's own chance of this, stated with the estimate: 5%; middle value at least 5.5-fold (0.74 log units) from the limit.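

In this assay compound 4 gives > 10000 nM, which is a limit and not a number, and it joins compound 1 at that limit: the limit of > 10000 nM in this assay, at which 2 of the 4 values shown sit. The step between these two compounds cannot be read, so it cannot be said whether 2-chlorobenzyl in place of (3-methoxyphenyl)carbonyl changes the read-out at all. Among the three benzyl ethers, the result shows that leaving the ester is not enough on its own to bring the number down: chloro in place of cyano gives an at least 10-fold higher number from compound 3 to compound 4 (1.00 log units; beyond the scatter), and chloro in place of fluoro gives an at least 3.4-fold higher number from compound 2 to compound 4 (0.53 log units; beyond the scatter), so the single substituent on the benzyl group decides much of the outcome, and chloro does not fall in line with the other two.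

The compounds shown do not tell how far compound 1 and compound 4 actually lie from the limit, nor why chloro parts from fluoro and cyano here. They also leave open whether a bromo, methyl or methoxy group on that aromatic carbon would follow chloro or follow cyano, and how an amine on the benzyl group would fare.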